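An Amino Group Added to an Inactive Core

This account rests on a few compounds, and the source may have more. Where it says the series, first, only, none or still open, it means among the compounds named here.

In a functional assay on Vero cells (Chlorocebus sabaeus) for inhibition (on this read-out lower numbers stand for stronger inhibition and higher numbers for weaker inhibition), compound 1 (`OC[C@H]1O[C@H](n2cnc3c(O)ncnc32)CS1`) gives > 100000 nM as its result, which is a limit of the assay and not a number. In this assay compound 2 (`O=c1ccn([C@H]2CS[C@@H](CO)O2)c(=O)[nH]1`) gives > 100000 nM as its result, again only a limit. In this assay compound 3 (`O=c1[nH]c(=O)n([C@@H]2CS[C@@H](CO)O2)cc1Cl`) gives > 100000 nM as its result, once more only a limit. Going by the values given here, compound 1 therefore has no true number to stand on, and the only evidence so far is the limit of > 100000 nM in this assay, at which 3 of the 3 values shown sit, for the whole set.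

Compound 4 (`Nc1nc(O)c2ncn([C@@H]3CS[C@@H](CO)O3)c2n1`) keeps the core of compound 1 and carries one change, amino in place of hydrogen on an aromatic carbon (amino in place of hydrogen on an aromatic carbon, between two ring nitrogen atoms). Among the compounds with values here, no step between measured compounds is available to size this change. The only anchor is the limit of compound 1 at > 100000 nM in this assay and that limit sets no scale. The estimated step is a number no higher from compound 1 to compound 4 (the limit leaves the size open) and it is expected to stay within the scatter, with any real movement going towards stronger inhibition. For compound 4 the estimated value is 100000 nM with an expected range from 25000 nM to 200000 nM and the assay may well report only a limit again.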

Compound 4, half-maximal inhibitory concentration: 63600 nM
Compound 4: middle estimate off by 1.6-fold (0.20 log units), on the high side, and the stated range covers the measured number.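

Going by these compounds alone, the amino group on an aromatic carbon, between two ring nitrogen atoms, gives the first true number in the set, and in this assay this change amounts to an at least 1.5-fold lower number from compound 1 to compound 4 (0.19 log units; that floor lies within the scatter). That figure is only a floor, and the real size of the step stays unknown, so the position is shown to tolerate the amino group and to yield a measurable result, but the change is not shown to move inhibition beyond the scatter. Compound 4 now stands apart from the other compounds shown, which give no number to compare with it, and the set as a whole still rests mainly on one limit: the limit of > 100000 nM in this assay, at which 3 of the 4 values shown sit.

What the compounds shown leave open is whether a different group on this same aromatic carbon, such as a methyl group or a dimethylamino group, would give a lower or a higher number than the amino group of compound 4. They also leave open whether replacing the hydroxy group on the same ring with a methoxy group would change the result while the amino group stays in place.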